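This account rests on a few compounds, and the source may have more. Where it says the series, first, only, none or still open, it means among the compounds named here.

In a functional assay on U-373MG ATCC cells (Homo sapiens) for cytotoxicity, read by MTT assay, with a stated time of 72 h (a lower number here means a stronger inhibitor, a higher number a weaker inhibitor), two compounds built on a shared core have been read so far. The value of compound 1 `O=C(c1ccccc1)c1sc(N2CCCC2)nc1Br` is a limit of the assay, > 100000 nM. Among the compounds with values here, compound 2 `O=C(c1ccccc1)c1sc(N2CCCCC2)nc1Cl` gives 96000 nM, the only actual number available, so there is no second number against which to rank it. Compound 3 `O=C(c1ccccc1)c1sc(N2CCCCC2)nc1Br` carries bromo in place of chloro on an aromatic carbon, next to the ring nitrogen, while the piperidin-1-yl group stays as it is in compound 2: bromo in place of chloro on an aromatic carbon. Within the data shown here, no measured step shows what this exchange does in this assay. A shift beyond the usual scatter is not expected, in either direction, and the expectation rests on compound 2 at 96000 nM. The estimated change is a 1.1-fold lower number from compound 2 to compound 3 (0.03 log units; within the scatter). Compound 3 is expected at 90000 nM, with an estimated range from 45000 nM to 180000 nM.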

Compound 3, half-maximal inhibitory concentration: 78000 nM
Compound 3: middle estimate off by 1.2-fold (0.06 log units), on the high side, within the range that was stated.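

In this assay, this position now has a measured exchange of one halogen for another, bromo in place of chloro, and the result is a 1.2-fold lower number from compound 2 to compound 3 (0.09 log units; within the scatter), so the two compounds cannot be told apart here. The change to piperidin-1-yl in place of pyrrolidin-1-yl, with bromo kept, gives an at least 1.2-fold lower number from compound 1 to compound 3 (0.10 log units; that floor lies within the scatter), a floor that shows no shift beyond the scatter and puts no upper bound on the true size of the step. That step cannot be sized further, since the value of compound 1 is a limit of the assay: the limit of > 100000 nM in this assay, at which 1 of the 3 values shown sits.

As far as these compounds go, whether a group other than a halogen at this position, such as an amine or a methoxy group, would move the number beyond the scatter remains open. So does the effect of a morpholin-4-yl group in place of the piperidin-1-yl group.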